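This account rests on a few compounds, and the source may have more. Where it says the series, first, only, none or still open, it means among the compounds named here.

Measured in an ADME assay on THP-1 cells (Homo sapiens) for cytotoxicity, read by resazurin assay, with a stated time of 72 h; on this read-out higher numbers stand for lower toxicity in this test and lower numbers for higher toxicity in this test:
compound 1, `CC(C)=CCOc1ccc(C(=O)/C=C/c2ccncc2)c(O)c1`, gives 16000 nM;
compound 2, `CC(C)=CCOc1ccc(C(=O)/C=C/c2cccnc2)c(O)c1`, gives 100000 nM;
compound 3, `C#CCOc1ccc(C(=O)/C=C/c2ccncc2)c(OC)c1`, gives 16000 nM.

For the measured compounds named here, the one measured pair differing in a single place is compound 1 and compound 2: the change is pyridin-3-yl in place of pyridin-4-yl on a double-bonded chain carbon bound to a double-bonded chain carbon, and the step is a 6.3-fold higher number from compound 1 to compound 2 (0.80 log units; beyond the scatter). Compound 3 stands level with compound 1 at the digits given, the two together being the lowest of the three numbers in this assay; how the core of compound 3 differs from the core of compound 1 is not broken down here.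

Compound 4, `C#CCOc1ccc(C(=O)/C=C/c2cccnc2)c(OC)c1`, is not yet measured. Going by the values given here, it differs from compound 3 by pyridin-3-yl in place of pyridin-4-yl on a double-bonded chain carbon bound to a double-bonded chain carbon, the same change as the one made between compound 1 and compound 2, at the same place. With only that single occurrence to go on, a step of like size is expected, because a 6.3-fold higher number from compound 1 to compound 2 (0.80 log units; beyond the scatter) is the one measured result of this change. The expected step is a 5.0-fold higher number from compound 3 to compound 4 (0.70 log units; beyond the scatter). For compound 4 the estimate in this assay is 80000 nM, with a range expected from 30000 nM to 200000 nM.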

Compound 4, half-maximal cytotoxic concentration: 16000 nM
Compound 4: middle estimate off by 5.0-fold (0.70 log units), on the high side; measured number outside the range, below it.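

In this assay, pyridin-3-yl in place of pyridin-4-yl gives no change at the digits printed from compound 3 to compound 4 (within the scatter), so the step seen on the core of compound 1 does not carry over to the core of compound 3: the same change on two cores in this assay, a 6.3-fold higher number (0.80 log units; beyond the scatter) from compound 1 to compound 2 and no change at the digits printed (within the scatter) from compound 3 to compound 4, 6.3-fold (0.80 log units) apart, beyond the scatter of two such steps

The size of this change therefore depends on the core in this series, and a step measured on one of these cores is no reliable guide to the step on the other. For the compounds shown here, with only two cores compared, the result does not show which part of the core is responsible, nor how the change would behave on any further core.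

Open, from the compounds shown here alone, is which of the differences between the core of compound 1 and the core of compound 3 decides the outcome, a question that a core carrying only one of those differences could settle. Also open, going by these compounds, is whether pyridin-2-yl or a plain phenyl, on a double-bonded chain carbon bound to a double-bonded chain carbon, would follow pyridin-3-yl or pyridin-4-yl on either core.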